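Trimming the oxazole substituent in a ketone series

The source may report more compounds than this note shows. Statements on the series, on what has been measured and on what is new or still open speak of the compounds shown alone.

Compounds measured so far:
compound 1 `COC(=O)c1cc(-c2cnc(C(=O)CCc3ccc(-c4ccccc4)cc3)o2)ccn1`, 1.5 nM
compound 2 `CNC(=O)c1cnc(C(=O)CCc2ccc(COc3ccccc3)cc2)o1`, 3.6 nM
compound 3 `COC(=O)c1ccc(-c2cnc(CCCc3ccc(-c4ccccc4)cc3)o2)nc1`, 50000 nM

In an assay for inhibition of Fatty-acid amide hydrolase 1 (Rattus norvegicus) (a higher number here means a weaker inhibitor, a lower number a stronger inhibitor), compound 1 gives the lowest number of the three. Compound 2 sits closest to it, with a number that is higher by a margin beyond the scatter. Compound 3 lies far away, with a number that is higher by a very large margin; compound 3 carries a three-carbon chain where compound 1 and compound 2 carry a ketone, and its result shows that this part of the molecule is not to be altered lightly.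

Compound 4 `CSc1cnc(C(=O)CCc2ccc(-c3ccccc3)cc2)o1` has not yet been measured. It keeps the ketone of compound 1 and differs from it in one place: methylsulfanyl in place of 2-(methoxycarbonyl)pyridin-4-yl on an aromatic carbon. The group that enters is small and sits on an aromatic carbon of the five-membered ring, next to the ring oxygen. Among the measured compounds shown here, nothing among the measured compounds shows what a group of this size does there. The step from compound 1 to compound 4 in this assay is expected to raise the number clearly beyond the scatter, a 100-fold higher number from compound 1 to compound 4 (2.00 log units; beyond the scatter). Compound 4 is therefore estimated to give 150 nM, with a plausible range from 30 nM to 800 nM.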

Compound 4, inhibition constant: 3 nM
The estimate for compound 4 lay 50-fold (1.70 log units) above the measured number, and the stated range ends above it.
By their numbers in this assay, from the lowest: compounds 1, 4 and 2 (each within the scatter of the next, the first and the last beyond it); then compound 3.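

In this assay, replacing 2-(methoxycarbonyl)pyridin-4-yl with methylsulfanyl on an aromatic carbon of the five-membered aromatic ring, next to the ring oxygen, gives a 2.0-fold higher number from compound 1 to compound 4 (0.30 log units; within the scatter). This position therefore does not depend on the larger group: its 10 heavy atoms, its six-membered aromatic ring and its double bond outside aromatic rings can all give way to a group of 2 heavy atoms with no ring, and the number stays within the scatter. Nothing available here accounts for why these two very different groups give results so close together.

The compounds shown leave open whether a bare hydrogen, an amine or a carboxylic acid would be accepted at this position as well, and whether a longer chain on the sulfur, such as ethylsulfanyl, would keep the number within the scatter of compound 4. They also leave open whether the ketone matters as much alongside methylsulfanyl as compound 3, which carries a three-carbon chain in its place, might suggest.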